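Fluoro on the core: a step with no measured precedent

A few compounds are considered here, and "the series" means these few. Any claim that something is new, unique, unknown or untested is made for them only; others in the source may bear on it.

Working notes on the series. Compound 1 `O=C(Cc1cccnc1)c1cc2ccccc2[nH]1` gives 13% in an in vitro assay on P815B cells for inhibition of Indoleamine 2,3-dioxygenase 1 (Mus musculus), tested at 20 uM; a lower number here means less inhibition, a higher number more inhibition at the concentration tested (going by the name of the read-out). Compound 3 `O=C(Cc1ccccn1)c1cc2ccccc2[nH]1` carries pyridin-2-yl in place of pyridin-3-yl on the saturated chain carbon bound to the carbonyl carbon; in this assay compound 3 gives 10%, and the change gives a number 3 percentage points lower from compound 1 to compound 3 (within the scatter). Compound 2 `Cn1c(C(=O)Cc2cccnc2)cc2ccccc21`, which bears a methyl group on the ring nitrogen of the core, gives "not active" (no number reported) in this assay, so no number is available for it. Among the two numbers in hand compound 1 has the higher one, but the gap to compound 3 is within the scatter and nothing separates the two.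

Compound 4 `O=C(Cc1cccnc1)c1cc2cc(F)ccc2[nH]1` differs from compound 1 by fluoro in place of hydrogen on an aromatic carbon. Within the data shown here, no measured step touches the six-membered aromatic ring of the core; the only measured step, from compound 1 to compound 3, concerns the pyridyl group and lies within the scatter. There is therefore nothing that points to a step beyond the scatter in this assay for this change, in either direction. Compound 4 is expected to give 13% (range 3% to 25%) in this assay. The expected step is no change at the digits printed from compound 1 to compound 4 (within the scatter).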

Compound 4, a percentage reported as inhibition, at one concentration (the size of the read-out at that concentration, not a potency): 24%
Beside the measured number, compound 4's estimate is 11 percentage points below it; the range from low to high includes it.
By their numbers in this assay, from the lowest: compounds 3 and 1 (each within the scatter of the next); then compound 4.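

In this assay, the change to the six-membered aromatic ring of the core gives a number 11 percentage points higher from compound 1 to compound 4 (beyond the scatter), a modest step and the first in the series to lie beyond the scatter, whereas a number 3 percentage points lower from compound 1 to compound 3 (within the scatter) left the pyridyl change within it. This aromatic carbon, meta to a fused ring and para to a fused ring, therefore accepts fluoro in place of hydrogen without loss of inhibition at the concentration tested, and the read-out responds to a change at this place on the core, not only to changes that can be tested on the side chain. No measurement among the data shown offers an explanation for this step.

Open, going by these compounds, is whether chloro, methoxy or an amine on this same carbon would move the read-out as fluoro does, and whether fluoro on the other aromatic carbons of that ring gives a step of similar size. Also open, on these data alone, is whether the step carries over to the pyridin-2-yl side chain of compound 3, and, with a single modest step at one concentration, how it would translate into potency.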